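A few compounds are considered here, and "the series" means these few. Any claim that something is new, unique, unknown or untested is made for them only; others in the source may bear on it.

Working notes on the coumarin-ether series, step from compound 3 to compound 4.

Compound 3 `COc1cc2ccc(=O)oc2cc1OCCCCBr` gives 11.2% in a functional assay on HUVEC cells (Homo sapiens) for inhibition, read by MTT assay, with a stated time of 24 h, tested at 10 uM (on this read-out higher numbers stand for more inhibition of growth at the one concentration tested and lower numbers for less inhibition of growth), the lowest of the three numbers recorded so far. Nearest to it stands compound 1 `COc1cc2ccc(=O)oc2cc1OCC(O)CN1CCCCC1`, which in this assay gives 31.4%, a gap beyond the scatter. Furthest from it stands compound 2 `COc1cc2ccc(=O)oc2cc1OCC1CO1`, which in this assay gives 62.2%. Within the data shown here, the one single-point step measured so far, a number 51 percentage points lower from compound 2 to compound 3 (beyond the scatter), shows that exchanging the oxiran-2-yl for the 3-bromopropyl on the chain costs most of the growth inhibition.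

Compound 4 `COc1cc2ccc(=O)oc2cc1OCCNC(C)C` is reached from compound 3 by isopropylamino in place of 2-bromoethyl on a saturated chain carbon, two bonds along the chain from an oxygen on an aromatic ring. Among the measured compounds shown here, no measured step covers a bromine-for-amine exchange directly. The only bearing is indirect: compound 1, whose chain also carries a basic amine, stands some way above compound 3, while compound 2, with no amine and no bromine, stands highest. The outcome in this assay is therefore uncertain; a moderate upward step is expected, in the direction of compound 1, rather than a return to the level of compound 2.

Estimate: compound 4 is expected to give 26% in this assay, within 10% to 45%, which corresponds to an expected step of a number 14.8 percentage points higher from compound 3 to compound 4 (beyond the scatter).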

Compound 4, percent growth inhibition at one concentration: 0.1%
Compound 4: the middle estimate sits 25.9 percentage points above what was measured, outside the stated range (below it).
By their numbers in this assay, from the lowest: compound 4; then compound 3; then compound 1; then compound 2.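

In this assay the isopropylamino group on this chain brings no recovery of growth inhibition: the step is a number 11.1 percentage points lower from compound 3 to compound 4 (beyond the scatter) and leaves compound 4 lower than the bromine-bearing chain of compound 3. The second step, a number 62.1 percentage points lower from compound 2 to compound 4 (beyond the scatter), shows that (isopropylamino)methyl in place of oxiran-2-yl removes practically all the growth inhibition held by compound 2, so both exchanges of oxiran-2-yl that can be read on this chain, to 3-bromopropyl and to (isopropylamino)methyl, go downward. Nothing on hand explains why these exchanges lower the number.

Still open, on these data alone, is whether the low reading belongs to the isopropylamino group itself or to its place on this short chain, a question that a longer chain ending in the same isopropylamino group, or a morpholine or a carboxylic acid at the chain end, would address. With only one concentration read, the compounds shown also leave open how compound 4 and its neighbours would behave across a range of concentrations.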